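This account rests on a few compounds, and the source may have more. Where it says the series, first, only, none or still open, it means among the compounds named here.

Three analogues built on one shared core have been tested in a functional assay on BGC-823 cells (Homo sapiens) for cytotoxicity, read by MTT assay, with a stated time of 48 h; on this read-out higher numbers stand for weaker inhibition and lower numbers for stronger inhibition. Compound 1 `O=C(CSc1nnc(-c2ccncc2)o1)N/N=C/c1ccc(Cl)cc1` gives 20500 nM. Compound 2 `O=C(CSc1nnc(-c2ccncc2)o1)N/N=C/c1ccc(O)cc1` gives 7940 nM. Compound 3 `O=C(CSc1nnc(-c2ccncc2)o1)N/N=C/c1ccccc1O` gives 6160 nM, sitting at the low end of the set, though the step of a 1.3-fold lower number from compound 2 to compound 3 (0.11 log units; within the scatter) is within the scatter; the steps of a 3.3-fold lower number from compound 1 to compound 3 (0.52 log units; beyond the scatter) and a 2.6-fold lower number from compound 1 to compound 2 (0.41 log units; beyond the scatter) both lie beyond it. Compound 4 `O=C(CSc1nnc(-c2ccncc2)o1)N/N=C/C=C/c1ccccc1` has not yet been measured in this assay. It differs from compound 3 in one place: 2-phenylethenyl in place of 2-hydroxyphenyl on a carbon with a double bond to nitrogen. Within the data shown here, no measured compound carries a 2-phenylethenyl group, so the only step that bears on this change is the one in which a hydroxy group entered, a 2.6-fold lower number from compound 1 to compound 2 (0.41 log units; beyond the scatter), a modest drop in number; here a hydroxy group is lost. Compound 4 is therefore expected to give a somewhat higher number than compound 3, an estimated step of a 1.9-fold higher number from compound 3 to compound 4 (0.29 log units; within the scatter), with wide uncertainty. The estimate for compound 4 is 12000 nM, expected to fall between 4000 nM and 40000 nM.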

Compound 4, half-maximal inhibitory concentration: 10600 nM
Compound 4: the middle estimate sits 1.1-fold (0.05 log units) above what was measured; the measured number falls inside the stated range.
By their numbers in this assay, from the lowest: compounds 3, 2, 4 and 1 (each within the scatter of the next, the first and the last beyond it).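

In this assay, 2-phenylethenyl on a carbon with a double bond to nitrogen stays within the scatter of all three earlier groups, with a 1.7-fold higher number from compound 3 to compound 4 (0.24 log units; within the scatter), a 1.3-fold higher number from compound 2 to compound 4 (0.13 log units; within the scatter) and a 1.9-fold lower number from compound 1 to compound 4 (0.29 log units; within the scatter). Among these compounds, compound 4 has no hydrogen-bond donor in this group and still cannot be told apart from compound 2 or compound 3, so the earlier steps from compound 1 to those hydroxy compounds do not show that a hydroxy group is needed at this place. Nothing available explains this result.

The compounds shown leave open how an amine or a carboxylic acid would read at this place, with no aromatic ring in the group. They also leave open whether a saturated 2-phenylethyl chain or a longer chain would read like 2-phenylethenyl.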